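This account rests on a few compounds, and the source may have more. Where it says the series, first, only, none or still open, it means among the compounds named here.

- compound 1 `Cc1cccc(C)c1-c1nc(CN2CCC(C(=O)NCCCN3C[C@H](C)C[C@H](C)C3)CC2)c(C)o1`: 0.0517 h
- compound 2 `COc1cccc(C)c1-c1nc(CN2CCC(C(=O)NCCCN3C[C@H](C)C[C@H](C)C3)CC2)c(C)o1`: 0.0767 h

In an ADME assay on microsomes from liver (Rattus norvegicus) for metabolic stability, read by LC-MS, using NADPH, at 37 degrees C (a higher number here means that the compound lasts longer, a lower number that the compound disappears faster), compound 2 gives 0.0767 h and compound 1 gives 0.0517 h, so the two stand together within the scatter. Compound 3 `Cc1cc(C)cc(-c2nc(CN3CCC(C(=O)NCCCN4C[C@H](C)C[C@H](C)C4)CC3)c(C)o2)c1` differs from compound 2 in one group: 3,5-dimethylphenyl in place of 2-methoxy-6-methylphenyl on an aromatic carbon. Among the compounds with values here, the one measured step that bears on this is a 1.5-fold higher number from compound 1 to compound 2 (0.17 log units; within the scatter), with methoxy in place of methyl on an aromatic carbon. Neither measured compound carries 3,5-dimethylphenyl, so that step is only a weak guide. No shift beyond the scatter is expected, and no direction can be argued. The estimated step is a 1.3-fold lower number from compound 2 to compound 3 (0.11 log units; within the scatter). For compound 3 the expected half-life is 0.06 h, with an estimated range of 0.025 h to 0.15 h.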

Compound 3, half-life: < 0.5 h
Compound 3 was reported as a limit; the forecaster's own chance of this, stated with the estimate: 5%; the middle value is on the limit's open side.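

In this assay compound 3 is reported only as a limit, < 0.5 h, so its steps from compound 1 and compound 2 cannot be read. On these data alone, whether compound 3 lasts longer or disappears faster than either compound stays open.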